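A few compounds are considered here, and "the series" means these few. Any claim that something is new, unique, unknown or untested is made for them only; others in the source may bear on it.

Measured so far in an ADME assay on microsomes from liver (Mus musculus) for metabolic stability, with a stated time of 10 min (a higher number here means that more of the compound is left, a lower number that less of the compound is left), are these compounds:

Compound 1 `Nc1c(C(=O)N[C@H]2CC[C@@H](c3ccc(OCc4ccccc4)cc3)CC2)[nH]c(=O)[nH]c1=O` gives 85%
Compound 2 `Nc1c(C(=O)N[C@@H]2CCCc3c(OCc4ccccc4)cccc32)[nH]c(=O)[nH]c1=O` gives 79%
Compound 3 `O=C(N[C@H]1CC[C@@H](c2ccccc2)CC1)c1[nH]c(=O)[nH]c(=O)c1O` gives 100%

Compound 3 holds the highest of the three numbers, and compound 1 and compound 2 both lie lower by more than the usual scatter. Compound 4 `CC(C)Cn1c(=O)[nH]c(C(=O)N[C@H]2CC[C@@H](c3ccccc3)CC2)c(O)c1=O` has not yet been measured. It differs from compound 3 by isobutyl in place of hydrogen on an aromatic nitrogen and nothing else. Among the compounds with values here, no measured pair shows this change on its own, so its effect can only be judged. Compound 3 starts from 100% so the number has room to hold or fall but not to rise. A fall beyond the scatter in this assay is expected, estimated as a number 28 percentage points lower from compound 3 to compound 4 (beyond the scatter) in size. For compound 4 the expected value is 72% with an estimated range from 48% to 92% in this measurement.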

Compound 4, percent of the compound remaining: 100%
Compound 4: the middle estimate sits 28 percentage points below what was measured; measured number above the stated range.
By their numbers in this assay, from the lowest: compounds 2 and 1 (each within the scatter of the next); then compounds 3 and 4 (each within the scatter of the next).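

In this assay, within the data shown here, isobutyl in place of hydrogen on an aromatic nitrogen gives no change at the digits printed from compound 3 to compound 4 (within the scatter), the first direct reading of a change at this position. So this nitrogen carries a chain of four carbons without any loss in this read-out, although the top of the scale leaves no room to see a rise. No measurement here explains why the number holds.

Going by these compounds, whether a longer chain, a benzyl group or a carboxylic acid on the same nitrogen would hold the number as well stays open. The compounds shown also leave open how isobutyl behaves on the core of compound 1, which carries an amine where compound 3 has a hydroxy group.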